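The source may hold more compounds than are shown below. What is called first, only, known or untested is meant among the compounds shown, and "the series" means these compounds.

Compound 1 `Cc1c(C(=O)Nc2ccc(Oc3ccnc4[nH]ccc34)c(F)c2)nnn1-c1ccccc1` gives 2340 nM in a functional assay on PC-3 cells (Homo sapiens) for cytotoxicity, read by MTT assay, with a stated time of 72 h; on this read-out lower numbers stand for stronger inhibition and higher numbers for weaker inhibition. Compound 2 `Cc1c(C(=O)Nc2ccc(Oc3ccnc4[nH]ccc34)cc2)nnn1-c1ccccc1F` gives 3450 nM. Compound 3 `O=C(Nc1ccc(Oc2ccnc3[nH]ccc23)c(F)c1)c1nnn(-c2ccccc2)c1C(F)(F)F` gives 2320 nM.

Compounds 1 and 3 share a core, and compound 3 carries trifluoromethyl in place of methyl on an aromatic carbon. That change made a 1.0-fold lower number from compound 1 to compound 3 (0.00 log units; within the scatter). The core of compound 2 differs from that of compound 1, but the difference between the two cores is not broken down here. Compound 4 `O=C(Nc1ccc(Oc2ccnc3[nH]ccc23)cc1)c1nnn(-c2ccccc2F)c1C(F)(F)F` has not yet been measured; it differs from compound 2 by trifluoromethyl in place of methyl on an aromatic carbon. This is the same kind of change as from compound 1 to compound 3, though the surroundings differ: the ring atom in compound 2 bears a 2-fluorophenyl group (7 heavy atoms) where compound 1 bears a phenyl group (6 heavy atoms). A step of similar size is expected here, a 1.0-fold lower number from compound 2 to compound 4 (0.02 log units; within the scatter), because the earlier change gave a 1.0-fold lower number from compound 1 to compound 3 (0.00 log units; within the scatter). Compound 4 is therefore estimated at 3300 nM in this assay, likely between 1700 nM and 6500 nM.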

Compound 4, half-maximal inhibitory concentration: 3690 nM
Compound 4: the middle estimate sits 1.1-fold (0.05 log units) below what was measured; the range from low to high includes it.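

In this assay, trifluoromethyl in place of methyl on the aromatic carbon gave a 1.1-fold higher number from compound 2 to compound 4 (0.03 log units; within the scatter). On both cores, the change produced a step too small to read, and the two steps agree: the same change on two cores in this assay, a 1.0-fold lower number (0.00 log units; within the scatter) from compound 1 to compound 3 and a 1.1-fold higher number (0.03 log units; within the scatter) from compound 2 to compound 4, 1.1-fold (0.03 log units) apart, within the scatter of two such steps

This shows that, for these two pairs, the swap carried over from one core to the other without a visible effect on the read-out, but two pairs cannot show that it would do the same on other cores, and they do not explain the result. The compounds shown leave open how this ring carbon would respond to a different kind of group, such as an amine, a carboxylic acid or a longer chain.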